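Shifting the Quinolinyl Attachment Point in Compound 4

This account rests on a few compounds, and the source may have more. Where it says the series, first, only, none or still open, it means among the compounds named here.

Three measured compounds share one core and differ only in the amine on the carbonyl carbon. In an assay on Sf21 cells for inhibition of MAP kinase-interacting serine/threonine-protein kinase 1 (Homo sapiens), read by luminescence and ADP-Glo, with stated times of 10 min and 40 min, tested at 500 nM (on this read-out higher numbers stand for more inhibition at the one concentration tested (going by the name of the read-out) and lower numbers for less inhibition), compound 1 `O=C(c1ccc(-c2ccc3ncc(-c4ccc5ncccc5c4)n3c2)cc1)N1CCC(N2CCCCC2)CC1` gives 62.8%, compound 2 `O=C(c1ccc(-c2ccc3ncc(-c4ccc5ncccc5c4)n3c2)cc1)N1CCOCC1` gives 74.7% and compound 3 `O=C(c1ccc(-c2ccc3ncc(-c4ccc5ncccc5c4)n3c2)cc1)N1CCNCC1` gives 73.5%. Compound 2 holds the highest of the three numbers, yet a number 1.2 percentage points lower from compound 2 to compound 3 (within the scatter), whereas a number 11.9 percentage points higher from compound 1 to compound 2 (beyond the scatter) and a number 10.7 percentage points higher from compound 1 to compound 3 (beyond the scatter). Compound 4 `O=C(c1ccc(-c2ccc3ncc(-c4cnc5ccccc5c4)n3c2)cc1)N1CCOCC1` keeps the morpholin-4-yl group of compound 2 and changes the other end instead: quinolin-3-yl in place of quinolin-6-yl on an aromatic carbon. Among the compounds with values here, none of the measured steps touches this position; all three vary the amine on the carbonyl carbon, so no measured step bears on this change and no direction can be read from them. Compound 4 is therefore expected to show a step of a number 12.7 percentage points lower from compound 2 to compound 4 (beyond the scatter), with a wide range. Compound 4 is estimated at 62%, between 25% and 88%.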

Compound 4, a percentage reported as inhibition, at one concentration (the size of the read-out at that concentration, not a potency): 71%
The estimate for compound 4 lay 9 percentage points below the measured number; the measured number falls inside the stated range.
By their numbers in this assay, from the lowest: compounds 1, 4, 3 and 2 (each within the scatter of the next, the first and the last beyond it).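

In this assay the first change away from the amine end gives a number 3.7 percentage points lower from compound 2 to compound 4 (within the scatter) with quinolin-3-yl in place of quinolin-6-yl and the morpholin-4-yl group held fixed. At this position, on the five-membered aromatic ring, the two attachment points of the quinoline therefore cannot be told apart at the one concentration tested. Nothing available explains this result. Going by these compounds, it remains open whether quinolin-3-yl behaves the same alongside the piperazin-1-yl amine of compound 3, and what a smaller group such as pyridin-3-yl or phenyl would give at this position.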